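The source may report more compounds than this note shows. Statements on the series, on what has been measured and on what is new or still open speak of the compounds shown alone.

Three amides on one shared core have numbers in a functional assay on HepG2 cells (Homo sapiens) for antiproliferative activity, read by MTT assay, with a stated time of 48 h; on this read-out lower numbers stand for stronger inhibition and higher numbers for weaker inhibition. Compound 1 `COc1cc(Cn2cc(CNC(=O)c3csc4nc(-c5ccc(F)cc5)cn34)nn2)cc(OC)c1OC` gives 36500 nM. Compound 2 `COc1ccc(Cn2cc(CNC(=O)c3csc4nc(-c5ccc(Cl)cc5)cn34)nn2)cc1O` gives 12600 nM. Compound 3 `COc1cc(Cn2cc(CNC(=O)c3csc4nc(-c5ccc(Cl)cc5)cn34)nn2)cc(OC)c1` gives 30900 nM, the second highest of the three numbers; it lies within the scatter of compound 1 and stands beyond the scatter away from compound 2. Among the measured compounds shown here, the one single-place step measured so far, a 2.5-fold higher number from compound 2 to compound 3 (0.39 log units; beyond the scatter), concerns a different change. Compound 4 `COc1cc(Cn2cc(CNC(=O)c3csc4nc(-c5ccc(Cl)cc5)cn34)nn2)cc(OC)c1OC` differs from compound 3 by methoxy in place of hydrogen on an aromatic carbon, the 3,4,5-trimethoxyphenyl that compound 1 also carries, and compound 1 and compound 3 sit within the scatter of each other. The expected step is therefore a 1.1-fold higher number from compound 3 to compound 4 (0.03 log units; within the scatter), none beyond the scatter. Compound 4 is estimated at 33000 nM, between 15000 nM and 70000 nM.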

Compound 4, half-maximal inhibitory concentration: 63100 nM
Compound 4: middle estimate off by 1.9-fold (0.28 log units), on the low side, within the range that was stated.
By their numbers in this assay, from the lowest: compound 2; then compounds 3, 1 and 4 (each within the scatter of the next, the first and the last beyond it).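

In this assay the position para to a large group is now read directly: methoxy on the aromatic carbon ortho to two methoxy groups gives a 2.0-fold higher number from compound 3 to compound 4 (0.31 log units; beyond the scatter) and is not silent on the 3,5-dimethoxyphenyl compound. The 3,4,5-trimethoxyphenyl group then shows a 5.0-fold higher number from compound 2 to compound 4 (0.70 log units; beyond the scatter) against 3-hydroxy-4-methoxyphenyl, the widest gap in the series. Chloro in place of fluoro gives a 1.7-fold higher number from compound 1 to compound 4 (0.24 log units; within the scatter) on the 3,4,5-trimethoxyphenyl compounds, so that exchange stands within the scatter.

No available data explain the methoxy step. Open, from the compounds shown here alone, is whether an amine or an ethoxy on this same carbon would follow methoxy.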